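Chloro in Place of Trifluoromethyl on a Weakly Active Pair

This account rests on a few compounds, and the source may have more. Where it says the series, first, only, none or still open, it means among the compounds named here.

Compound 2 `COc1cc(Cl)cc(-c2nn(-c3cccc(NC(=O)Nc4ccc(Cl)c(C(F)(F)F)c4)c3)cc2-c2ccncc2)c1` and compound 1 `O=C(Nc1cccc(-n2cc(-c3ccncc3)c(-c3cc(O)cc(Cl)c3)n2)c1)Nc1ccc(Cl)c(Cl)c1` share one core and differ only in the group on their outer ring. In a functional assay on CCRF-CEM cells (Homo sapiens) for inhibition, read by sulforhodamine B assay, with a stated time of 48 h, tested at 0.1 uM (a higher number here means a weaker effect of the compound at the concentration tested, a lower number a stronger effect), compound 2 gives 97% and compound 1 gives 95%; the two numbers lie within the scatter of each other, so neither can be called the weaker or the stronger, and both show little effect at the concentration tested. For the measured compounds named here, no step between measured compounds that differ in a single place is available, so the two values show only that the pair behaves alike.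

Compound 3 `COc1cc(Cl)cc(-c2nn(-c3cccc(NC(=O)Nc4ccc(Cl)c(Cl)c4)c3)cc2-c2ccncc2)c1` has not yet been measured. It differs from compound 2 by chloro in place of trifluoromethyl on an aromatic carbon. Compound 3 thus carries the 3,4-dichlorophenyl grouping already found in compound 1 while keeping the remainder of compound 2. The step of a number 2 percentage points lower from compound 2 to compound 3 (within the scatter) is expected to be none beyond the scatter, since compound 1 with the same 3,4-dichlorophenyl group gives 95% in this assay. Compound 3 is therefore estimated at 95%, within 85% to 102%.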

Compound 3, a percentage reported as activity, at one concentration (the size of the read-out at that concentration, not a potency): 97%
Beside the measured number, compound 3's estimate is 2 percentage points below it, within the range that was stated.
By their numbers in this assay, from the lowest: compounds 1, 2 and 3 (each within the scatter of the next).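

Chloro in place of trifluoromethyl on this aromatic carbon, ortho to a chloro group and meta to a large group, gives no change at the digits printed from compound 2 to compound 3 (within the scatter) in this assay, the first reading of this change on its own. Compound 3 also links compound 1 to the series through a single change, and methyl in place of hydrogen on the oxygen on the aromatic ring gives a number 2 percentage points higher from compound 1 to compound 3 (within the scatter) in the same assay. Neither step lies beyond the scatter, so at this one concentration neither place, with these groups, separates the compounds, which all show little effect.

No other measurement bears on these results, so the data offer no explanation for the alike numbers.

As far as these compounds go, whether an amine or a carboxylic acid on this aromatic carbon, or a longer chain such as ethyl or propyl on the oxygen, would shift the read-out remains open. Also open, from the compounds shown here alone, is whether these compounds would separate at other concentrations, since a single-concentration read-out with so little effect gives no measure of potency.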